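Series notes: amine side chain variation at the tertiary nitrogen

The source may report more compounds than this note shows. Statements on the series, on what has been measured and on what is new or still open speak of the compounds shown alone.

Measured so far:
compound 1, `c1ccc2c(c1)CN[C@@H](CN(CCCCNC1CCOCC1)[C@H]1CCCc3cccnc31)C2`, 29.4 nM
compound 2, `NCc1ccccc1CN(C[C@H]1Cc2ccccc2CN1)[C@H]1CCCc2cccnc21`, 50.8 nM

In a functional assay on cells for antagonist activity at C-X-C chemokine receptor type 4 (Homo sapiens), read by fluorescence and calcium flux, with stated times of 25 min and 90 s (a lower number here means a stronger inhibitor, a higher number a weaker inhibitor), compound 2 gives the higher of the two numbers, with compound 1 nearest, a step of a 1.7-fold higher number from compound 1 to compound 2 (0.24 log units; within the scatter), so the two stand within the scatter of each other. Compound 3, `CC(C)(CCN)CN(C[C@H]1Cc2ccccc2CN1)[C@H]1CCCc2cccnc21`, differs from compound 2 by a group of 6 heavy atoms (5 carbon, 1 nitrogen; no ring) in place of a group of 8 heavy atoms (7 carbon, 1 nitrogen; one six-membered aromatic ring of carbon only), on a saturated chain carbon bound to an amine nitrogen. Going by the values given here, the only step that bears on this is the one from compound 1 to compound 2, where a chain carrying an amine in place of the 2-(aminomethyl)phenyl group changed the number little. The step is therefore expected to be a 1.3-fold lower number from compound 2 to compound 3 (0.10 log units; within the scatter), no larger than the scatter. Compound 3 is estimated at 40 nM, within 12 nM to 150 nM.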

Compound 3, half-maximal inhibitory concentration: > 33300 nM
Compound 3 was reported as a limit (the forecaster's own chance of this, stated with the estimate: 3%); middle value at least 830-fold (2.92 log units) from the limit.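

Compound 3 stands only as a limit: the limit of > 33300 nM in this assay, at which 1 of the 3 values shown sits.
The place on a saturated chain carbon bound to an amine nitrogen, which looked tolerant between the first two compounds, proves highly sensitive to the group it carries. Putting the ring-free group in place of 2-(aminomethyl)phenyl gives a large loss (an at least 650-fold higher number from compound 2 to compound 3 (2.81 log units; beyond the scatter)), and the same group is just as far from the oxane-bearing chain (an at least 1100-fold higher number from compound 1 to compound 3 (3.05 log units; beyond the scatter)).

The compounds shown do not separate the branching of the chain in compound 3 from its length or from the missing ring. An unbranched 4-aminobutyl chain would bear on this.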